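From pyridin-2-yl to 4-hydroxyphenyl on a triple-bonded carbon

The compounds below may be only part of what the source reports. "The series", "measured", "known", "first", "only" and "open" are said of these compounds alone.

Measured so far in a functional assay on SF-295 cells (Homo sapiens) for cytotoxicity; a lower number here means a stronger inhibitor of growth, a higher number a weaker inhibitor of growth (values follow each compound):
- compound 1 (`OCCCCC#Cc1ccccc1C#Cc1ccccn1`) gives 21800 nM in this series
- compound 2 (`COc1cccc(C#Cc2ccccc2C#CCCCCO)c1`) gives 7900 nM in this series

Compound 1 has the higher of these two numbers, which makes it the weaker inhibitor of growth of the pair, and its gap to compound 2 lies beyond the usual scatter. Compound 3 (`OCCCCC#Cc1ccccc1C#Cc1ccc(O)cc1`) has not yet been measured. It differs from compound 1 in one place, where 4-hydroxyphenyl stands in place of pyridin-2-yl on a triple-bonded carbon (4-hydroxyphenyl in place of pyridin-2-yl on a triple-bonded carbon). Within the data shown here, no step between measured compounds that differ in one place is available in this assay to guide the expectation. Among the measured compounds shown here, the only other reading is compound 2 at 7900 nM and it points, weakly, towards a lower number than that of compound 1. A modest fall is therefore expected, near the scatter or a little past it. The expected change is a 2.2-fold lower number from compound 1 to compound 3 (0.34 log units; beyond the scatter) and it remains an estimate. For compound 3 the value is estimated at 10000 nM (expected range 4000 nM to 25000 nM).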

Compound 3, concentration for 50% growth inhibition: 16200 nM
The estimate for compound 3 lay 1.6-fold (0.21 log units) below the measured number; the range from low to high includes it.
By their numbers in this assay, from the lowest: compound 2; then compounds 3 and 1 (each within the scatter of the next).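

In this assay, 4-hydroxyphenyl in place of pyridin-2-yl on a triple-bonded carbon gives a 1.3-fold lower number from compound 1 to compound 3 (0.13 log units; within the scatter) and so stays within the scatter. Among these compounds, this is the first step that changes one place only, and it shows that these two groups cannot be told apart in this assay at this position. That holds even though the entering group is a ring of carbon only with 1 hydrogen-bond donor, while the leaving group is a ring with 1 hetero atom and 0 hydrogen-bond donors. No measurement at hand accounts for this result.

Among the compounds shown here, a single step cannot show whether this position is insensitive in general, since it covers only one pair of groups in one assay. From the compounds shown here alone, it remains open whether a carboxylic acid or an amine on the ring at this position, or a longer chain in place of the chain on the other triple bond of the shared core, would move the number beyond the scatter.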